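What a longer chain might do in this series

The source may report more compounds than this note shows. Statements on the series, on what has been measured and on what is new or still open speak of the compounds shown alone.

In a functional assay on HL-60 cells (Homo sapiens) for cytotoxicity, read by MTT assay, with a stated time of 48 h (on this read-out lower numbers stand for stronger inhibition and higher numbers for weaker inhibition), three compounds share one core and differ in a single side group. Compound 1 `CCCCCCCCCC(=O)N[C@@H](CCCNC(=N)N)C(=O)Nc1ccn([C@H]2O[C@@H](CO)[C@H](O)[C@H]2O)c(=O)n1` gives 584 nM, compound 2 `CCCCCCCCCC(=O)N[C@@H](CCC(=O)O)C(=O)Nc1ccn([C@H]2O[C@@H](CO)[C@H](O)[C@H]2O)c(=O)n1` gives 1860 nM, and compound 3 `CCCCCCCCCC(=O)N[C@@H](CCSC)C(=O)Nc1ccn([C@H]2O[C@@H](CO)[C@H](O)[C@H]2O)c(=O)n1` gives 280 nM, the lowest of the three numbers.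

Compound 4 `CCCCCCCCCCCCCC(=O)N[C@@H](CCSC)C(=O)Nc1ccn([C@H]2O[C@@H](CO)[C@H](O)[C@H]2O)c(=O)n1` differs from compound 3 in one place: butyl in place of hydrogen on a saturated chain carbon, nine bonds along the chain from a carbonyl carbon. This puts butyl in place of hydrogen on a saturated chain carbon, nine bonds along the chain from a carbonyl carbon.

Three measured steps show how far this series has moved so far: a 3.2-fold higher number from compound 1 to compound 2 (0.50 log units; beyond the scatter), a 2.1-fold lower number from compound 1 to compound 3 (0.32 log units; beyond the scatter) and a 6.6-fold lower number from compound 2 to compound 3 (0.82 log units; beyond the scatter). All three lie beyond the scatter, yet all three come from a change elsewhere, three bonds along the chain from an amide-type nitrogen and a carbonyl carbon. For the measured compounds named here, no measured pair differs in the chain that grows here, so these steps give a sense of scale but no direction. With no direction to go on, the best single expectation is no step beyond the scatter, held with little confidence. The expected step is a 1.1-fold higher number from compound 3 to compound 4 (0.03 log units; within the scatter). For compound 4 the estimated value is 300 nM, with an expected range from 90 nM to 1000 nM.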

Compound 4, half-maximal inhibitory concentration: 272 nM
For compound 4 the middle estimate is 1.1-fold (0.04 log units) above the measured one, within the range that was stated.
By their numbers in this assay, from the lowest: compounds 4 and 3 (each within the scatter of the next); then compound 1; then compound 2.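

In this assay, for the compounds shown here, this is the first measured step at the end of the chain, and putting butyl in place of hydrogen on a saturated chain carbon, nine bonds along the chain from a carbonyl carbon, gives a 1.0-fold lower number from compound 3 to compound 4 (0.01 log units; within the scatter), which lies within the scatter. Going by these compounds alone, all the earlier steps lay beyond the scatter and came from swapping the side group, so this pair shows that, with the methylsulfanyl side group held fixed, compound 3 and compound 4 cannot be told apart on this read-out even though the chain differs by a whole butyl group. No measurement offered here gives a reason for this result.

This single pair cannot say whether the same butyl change would read the same way with the side groups of compound 1 or compound 2, since each of those is shown with only one chain length. It also leaves open how a still longer chain at this place, or a chain ending in an amine or a carboxylic acid, would read in this assay.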